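The source may hold more compounds than are shown below. What is called first, only, known or untested is meant among the compounds shown, and "the series" means these compounds.

Series notes. Among the compounds with values here, compound 2 `Cc1cc(Nc2ccc(C(=O)/C=C/c3ccc(C(F)(F)F)cc3)cc2)n2nc(SCc3nc4ccccc4[nH]3)nc2n1` gives 1850 nM in a functional assay on SW-620 cells (Homo sapiens) for cytotoxicity, read by MTT assay, with stated times of 4 h and 72 h, tested at 2 uM (a lower number here means a stronger inhibitor, a higher number a weaker inhibitor), the highest of the three numbers so far. Compound 1 `Cc1cc(Nc2ccc(C(=O)/C=C/c3ccccc3Cl)cc2)n2nc(SCc3nc4ccccc4[nH]3)nc2n1` gives 680 nM in this assay, and compound 3 `Cc1cc(Nc2ccc(C(=O)/C=C/c3ccc(Cl)cc3)cc2)n2nc(SCc3nc4ccccc4[nH]3)nc2n1` gives 230 nM. Both gaps from compound 2 lie beyond the scatter: a 2.7-fold higher number from compound 1 to compound 2 (0.43 log units; beyond the scatter) and an 8.0-fold lower number from compound 2 to compound 3 (0.91 log units; beyond the scatter). Compound 4 `Cc1cc(Nc2ccc(C(=O)/C=C/c3ccc(F)cc3)cc2)n2nc(SCc3nc4ccccc4[nH]3)nc2n1` differs from compound 2 by fluoro in place of trifluoromethyl on an aromatic carbon. Within the data shown here, the one measured step that bears on this is the one in which trifluoromethyl also leaves an aromatic carbon, for chloro, and it gave an 8.0-fold lower number from compound 2 to compound 3 (0.91 log units; beyond the scatter). A lower number is therefore expected for compound 4 in this assay, with a step of roughly a 4.6-fold lower number from compound 2 to compound 4 (0.67 log units; beyond the scatter) in that direction. Compound 4 is estimated at 400 nM, within a range from 150 nM to 1000 nM.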

Compound 4, half-maximal inhibitory concentration: 85 nM
The estimate for compound 4 lay 4.7-fold (0.67 log units) above the measured number; the whole stated range lies above it.
By their numbers in this assay, from the lowest: compound 4; then compound 3; then compound 1; then compound 2.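

In this assay, within the data shown here, fluoro on this aromatic carbon, para to a large group, goes beyond chloro, with a 2.7-fold lower number from compound 3 to compound 4 (0.43 log units; beyond the scatter), and replacing trifluoromethyl gives a 22-fold lower number from compound 2 to compound 4 (1.34 log units; beyond the scatter), the only large step so far. Compound 4 also improves on the 2-chlorophenyl compound, with an 8.0-fold lower number from compound 1 to compound 4 (0.90 log units; beyond the scatter), and its steps to all three others lie beyond the scatter. No measurement shown accounts for this order of the groups. On these data alone, whether a methoxy group or an amine on this aromatic carbon would fit the order of trifluoromethyl, chloro and fluoro remains open.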